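This account rests on a few compounds, and the source may have more. Where it says the series, first, only, none or still open, it means among the compounds named here.

Measured compounds:

- compound 1 `O=C(/C(=N/O)Nc1ccc(F)c(Br)c1)C1CCN(C(=O)NCc2ccccc2)CC1`: in an assay for inhibition of Tryptophan 2,3-dioxygenase (Homo sapiens), with a stated time of 1 h (on this read-out lower numbers stand for stronger inhibition and higher numbers for weaker inhibition), compound 1 gives 89800 nM
- compound 2 `O=C(/C(=N/O)Nc1ccc(F)c(Br)c1)[C@H]1CC[C@H](NS(=O)(=O)Nc2ccccc2)CC1`: in this assay compound 2 gives only a limit, > 100000 nM
- compound 3 `NS(=O)(=O)NC[C@H]1CC[C@H](C(=O)/C(=N/O)Nc2ccc(F)c(Br)c2)CC1`: in this assay compound 3 gives 58700 nM

All three share the core with the oxime and the fluoro-bromo-substituted anilino group and differ in what hangs on the saturated ring. Compound 1 and compound 3 sit within the usual scatter of one another, so no order between them can be drawn from these two numbers. Compound 2 gives only a limit of this assay, (the limit of > 100000 nM in this assay, at which 1 of the 3 values shown sits), and no number. Within the data shown here, no two measured compounds differ in a single place, so no measured step exists.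

Compound 4 `O=C(/C(=N/O)Nc1ccc(F)c(Br)c1)C1CCN(C(=O)c2ccccc2)CC1` is not yet measured. It differs from compound 1 in one place: phenyl in place of benzylamino on a carbonyl carbon, which, cut one bond further out, reads benzylcarbamoyl to benzoyl. Among the measured compounds shown here, no measured step informs this change. Given that compound 1 gives 89800 nM and the whole series sits in the weak range, the expected step of a 1.1-fold lower number from compound 1 to compound 4 (0.05 log units; within the scatter) is nothing beyond the scatter, in either direction. Compound 4 is therefore expected at 80000 nM, with a range from 30000 nM to 200000 nM.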

Compound 4, half-maximal inhibitory concentration: > 100000 nM
Compound 4 gave a limit, no number (the forecaster's own chance of this, stated with the estimate: 35%); middle value at least 1.2-fold (0.09 log units) away from the limit.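

In this assay compound 4 gives only a limit, not a number: the limit of > 100000 nM in this assay, at which 2 of the 4 values shown sit. Among these compounds, the first measured step reads an at least 1.1-fold higher number from compound 1 to compound 4 (0.04 log units; that floor lies within the scatter) for phenyl in place of benzylamino on a carbonyl carbon, and as its floor lies within the scatter, a real loss cannot be told from no change. The step does show that going from benzylcarbamoyl to benzoyl, which removes the amide hydrogen of the benzylamino group, gives no measurable gain in inhibition at this position.

On these data alone, the true size of the step stays unknown without a number for compound 4. Also open, as far as these compounds go, is whether a carboxylic acid, an amine or a longer chain on this carbonyl carbon would bring a value clearly below the weak range of the series.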